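Chloro substitution on the outer phenyl of compound 3

A few compounds are considered here, and "the series" means these few. Any claim that something is new, unique, unknown or untested is made for them only; others in the source may bear on it.

Measured compounds:
compound 1, `COc1ccc(NCCNC(=O)[C@H](CC2CCCCC2)NC(=O)c2ccc3ccccc3c2)cc1`; in an assay on isolated protein for inhibition of cathepsin S (Homo sapiens), at 37 degrees C, at pH 5.5 (on this read-out higher numbers stand for weaker inhibition and lower numbers for stronger inhibition), compound 1 gives 5 nM
compound 2, `COc1ccc(NCCNC(=O)[C@H](CC2CCCCC2)NC(=O)c2ccc(Nc3nc(C)cc(C)n3)cc2)cc1`; in this assay compound 2 gives 2 nM
compound 3, `COc1ccc(NCCNC(=O)[C@H](CC2CCCCC2)NC(=O)c2ccc(-c3ccccc3)cc2)cc1`; in this assay compound 3 gives 9.1 nM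

Compound 3 stands at the highest of the three numbers. Its gap to compound 1, a 1.8-fold higher number from compound 1 to compound 3 (0.26 log units; within the scatter), lies within the scatter, so no order between these two can be read. Its gap to compound 2, a 4.6-fold higher number from compound 2 to compound 3 (0.66 log units; beyond the scatter), lies beyond the scatter and is the only clear separation in the set.

Compound 4, `COc1ccc(NCCNC(=O)[C@H](CC2CCCCC2)NC(=O)c2ccc(-c3cccc(Cl)c3)cc2)cc1`, differs from compound 3 by chloro in place of hydrogen on an aromatic carbon; cut one bond further out, the change reads phenyl to 3-chlorophenyl.

Neither measured step touches a substituent on the outer phenyl ring of compound 3. The step of a 1.8-fold higher number from compound 1 to compound 3 (0.26 log units; within the scatter) exchanges the whole group on the carbonyl carbon and stays within the scatter; the step of a 4.6-fold higher number from compound 2 to compound 3 (0.66 log units; beyond the scatter) exchanges the group on the aromatic carbon of the inner ring. Nothing in the series speaks to a single chloro on the outer ring. The expected step is therefore a 1.3-fold lower number from compound 3 to compound 4 (0.11 log units; within the scatter), that is, none beyond the scatter in either direction. For compound 4 the estimate in this assay is 7 nM, expected to fall between 2.5 nM and 20 nM.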

Compound 4, inhibition constant: 7.4 nM
Compound 4: middle estimate off by 1.1-fold (0.02 log units), on the low side; the range from low to high includes it.
By their numbers in this assay, from the lowest: compound 2; then compounds 1, 4 and 3 (each within the scatter of the next).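

In this assay, chloro in place of hydrogen on an aromatic carbon of the outer phenyl, the only substituent on that ring among the compounds shown, gives a 1.2-fold lower number from compound 3 to compound 4 (0.09 log units; within the scatter) and so leaves 3-chlorophenyl and phenyl indistinguishable at this position. The step of a 3.7-fold higher number from compound 2 to compound 4 (0.57 log units; beyond the scatter) remains beyond the scatter, so the single chloro does not remove the one clear separation in the set, which still lies between the (4,6-dimethylpyrimidin-2-yl)amino group and the biaryl groups. No supporting measurement accompanies these numbers that could say why the chloro leaves the read-out within the scatter.

On these data alone, the result covers one atom at one place, so it remains open whether a larger or differently built group there, such as a methoxy, an aminomethyl or a carboxylic acid, would also stay within the scatter of compound 3. As far as these compounds go, it is equally open whether chloro elsewhere on the outer ring, or a second chloro, would behave as this one does, and whether an outer pyridine ring in place of the phenyl would approach compound 2.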